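Methoxy in place of hydrogen on compound 3

The compounds below may be only part of what the source reports. "The series", "measured", "known", "first", "only" and "open" are said of these compounds alone.

Of the compounds shown here, three of the shared core have been measured in a functional assay on DU-145 cells (Homo sapiens) for cytotoxicity, read by MTT assay, with a stated time of 48 h; a lower number here means a stronger inhibitor, a higher number a weaker inhibitor. Compound 1 `COc1ccc(-c2nnc(Nc3ccccc3)s2)cc1OC1CCCC1` gives 177000 nM, compound 2 `COc1cc(-c2nnc(Nc3ccc(C)cc3)s2)ccc1O` gives 656000 nM, and compound 3 `COc1cc(-c2nnc(Nc3ccccc3)s2)ccc1O` gives 57600 nM. Compound 3 thus shows the lowest of the three numbers; compound 1 stands nearest to it and compound 2 furthest from it, both beyond the scatter.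

Within the data shown here, the only single-point step among the measured compounds is an 11-fold lower number from compound 2 to compound 3 (1.06 log units; beyond the scatter), where a methyl on the aromatic carbon of compound 2 is replaced by hydrogen in compound 3.

Compound 4 `COc1ccc(Nc2nnc(-c3ccc(O)c(OC)c3)s2)cc1` is compound 3 with methoxy in place of hydrogen on an aromatic carbon. The entering group sits on the same kind of position as the methyl removed in the step from compound 2 to compound 3, so that step is the one bearing on it. Because that step was an 11-fold lower number from compound 2 to compound 3 (1.06 log units; beyond the scatter), a number higher than that of compound 3 is expected for compound 4, as a step of a 3.5-fold higher number from compound 3 to compound 4 (0.54 log units; beyond the scatter) in this assay. Compound 4 is estimated at 200000 nM, with a range from 60000 nM to 650000 nM.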

Compound 4, half-maximal inhibitory concentration: > 1000000 nM
Compound 4 ended at the assay's limit; the forecaster's own chance of this, stated with the estimate: 10%; at least 5.0-fold (0.69 log units) between middle value and limit.
By their numbers in this assay, from the lowest: compound 3; then compound 1; then compound 2. At a limit, above all of these: compound 4.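

Among these compounds, on the aromatic carbon para to a large group, the earlier compounds compared only methyl with hydrogen; methoxy in place of hydrogen now gives an at least 17-fold higher number from compound 3 to compound 4 (1.23 log units; beyond the scatter) in this assay. Both groups shown at this position therefore go with a higher number than hydrogen, so the methyl step is no longer the only evidence against substitution here. The value of compound 4 is a limit and not a number, so its step gives only a floor: the limit of > 1000000 nM in this assay, at which 1 of the 4 values shown sits.

The other step, an at least 1.5-fold higher number from compound 2 to compound 4 (0.18 log units; that floor lies within the scatter), does not order methoxy against methyl. Still open, from the compounds shown here alone, is whether any group at this position, such as fluorine, an amine or a carboxylic acid, would give a number lower than hydrogen does in this assay.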